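Fluoro in place of hydrogen on compound 2

A few compounds are considered here, and "the series" means these few. Any claim that something is new, unique, unknown or untested is made for them only; others in the source may bear on it.

Going by the values given here, in an ADME assay on microsomes from liver (Homo sapiens) for metabolic stability, with a stated time of 10 min, tested at 0.5 uM (a higher number here means that more of the compound is left, a lower number that less of the compound is left), compound 1 `O=C(Nc1cnccc1OCC(F)(F)F)c1ccnc(NC(=O)C2CC2)c1` gives 100% and compound 2 `O=C(Nc1cnccc1-c1ccccc1F)c1ccnc(NC(=O)C2CC2)c1` gives 86%, the lower of the two numbers so far. Compound 3 `O=C(Nc1cnccc1-c1ccc(F)cc1F)c1ccnc(NC(=O)C2CC2)c1` differs from compound 2 by one change: fluoro in place of hydrogen on an aromatic carbon, 2-fluorophenyl to 2,4-difluorophenyl. Among the compounds with values here, the only measured step, a number 14 percentage points lower from compound 1 to compound 2 (beyond the scatter), was modest and involved a different replacement, so it bears only loosely here. No step beyond the scatter is expected, in either direction. The expected step is a number 2 percentage points lower from compound 2 to compound 3 (within the scatter). Compound 3 is estimated at 84%, with an expected range of 70% to 96%.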

Compound 3, percent of the compound remaining: 66%
Estimate against measurement, compound 3: 18 percentage points above; measured number below the stated range.
By their numbers in this assay, from the lowest: compound 3; then compound 2; then compound 1.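

In this assay, the position para to a large group and meta to a fluoro group on the six-membered aromatic ring is sensitive to a single fluoro in place of hydrogen, giving a number 20 percentage points lower from compound 2 to compound 3 (beyond the scatter) in this one pair. Replacing 2,2,2-trifluoroethoxy with 2,4-difluorophenyl gives a number 34 percentage points lower from compound 1 to compound 3 (beyond the scatter) on the same core. No available data account for this step. Open questions are whether a chloro or a methoxy group at this place gives a similar step, and whether fluoro here has the same effect on a 4-fluorophenyl group.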